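A few compounds are considered here, and "the series" means these few. Any claim that something is new, unique, unknown or untested is made for them only; others in the source may bear on it.

Three compounds share one core and differ only in the group carried on the benzyl arm. Compound 1 `COc1cccc(CN2Cc3c(NC(=O)c4ccccc4)n[nH]c3C2(C)C)c1` gives 1120 nM in an assay on Sf21 cells for inhibition of high affinity nerve growth factor receptor (Homo sapiens), read by HTRF, with a stated time of 30 min, in the presence of a further agent that is not named here; a lower number here means a stronger inhibitor, a higher number a weaker inhibitor. Compound 2 `CC1(C)c2[nH]nc(NC(=O)c3ccccc3)c2CN1Cc1cccc(I)c1` gives 1360 nM in this assay. Compound 3 `CC1(C)c2[nH]nc(NC(=O)c3ccccc3)c2CN1Cc1cccc(Br)c1` gives 940 nM in this assay, the lowest of the three numbers, although the steps of a 1.2-fold lower number from compound 1 to compound 3 (0.08 log units; within the scatter) and a 1.4-fold lower number from compound 2 to compound 3 (0.16 log units; within the scatter) both lie within the scatter. Compound 4 `CC1(C)c2[nH]nc(NC(=O)c3ccccc3)c2CN1Cc1ccccc1F` carries 2-fluorophenyl in place of 3-bromophenyl on a saturated chain carbon bound to an amine nitrogen in a ring. Among the compounds with values here, none of the measured steps changes the substitution pattern of that ring; each only swaps one group for another, and a 1.2-fold higher number from compound 1 to compound 2 (0.08 log units; within the scatter) was also within the scatter. The step of a 1.2-fold higher number from compound 3 to compound 4 (0.07 log units; within the scatter) is therefore expected to stay within the scatter. Compound 4 is expected to give 1100 nM, with a range from 450 nM to 2700 nM.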

Compound 4, half-maximal inhibitory concentration: 450 nM
Compound 4: the middle estimate sits 2.4-fold (0.39 log units) above what was measured; the measured number falls inside the stated range.
By their numbers in this assay, from the lowest: compound 4; then compounds 3, 1 and 2 (each within the scatter of the next).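

Unlike the swaps among the earlier arms, these changes move the number beyond the scatter, so this position on the saturated chain carbon can affect the result. Putting 2-fluorophenyl in place of the other arms gives a 2.1-fold lower number from compound 3 to compound 4 (0.32 log units; beyond the scatter) and a 3.0-fold lower number from compound 2 to compound 4 (0.48 log units; beyond the scatter) and a 2.5-fold lower number from compound 1 to compound 4 (0.40 log units; beyond the scatter) in steps that are all modest. No available evidence explains this difference.

Each step changes both the group on the ring and where it sits, leaving open which of the two matters. Going by these compounds, how an arm bearing an amine or a carboxylic acid would behave also remains open.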